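The source may report more compounds than this note shows. Statements on the series, on what has been measured and on what is new or still open speak of the compounds shown alone.

Among the measured compounds shown here, in an ADME assay on HEK293 cells (Homo sapiens) for inhibition, read by MTT assay, with a stated time of 3 days (a higher number here means a weaker inhibitor, a lower number a stronger inhibitor), only two compounds have numbers so far. Here compound 1 `C/C=C/COc1cc(/C=C\c2cc(OC)c(OC)c(OC)c2)ccc1OC` gives 135000 nM and compound 2 `COc1cccc(/C=C/CCCOc2cc(/C=C\c3cc(OC)c(OC)c(OC)c3)ccc2OC)c1` gives 39000 nM, so compound 2 holds the lower of the two numbers. The next structure, compound 3 `COCOc1ccc(/C=C/CCCOc2cc(/C=C\c3cc(OC)c(OC)c(OC)c3)ccc2OC)cc1`, keeps the shared core and the chain and alters only the far end of the molecule: 4-(methoxymethoxy)phenyl in place of 3-methoxyphenyl on a double-bonded chain carbon bound to a double-bonded chain carbon. In words, 4-(methoxymethoxy)phenyl stands in place of 3-methoxyphenyl on a double-bonded chain carbon bound to a double-bonded chain carbon.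

For the measured compounds named here, only one measured step offers guidance, a 3.5-fold lower number from compound 1 to compound 2 (0.54 log units; beyond the scatter). That modest step replaced prop-1-en-1-yl with 4-(3-methoxyphenyl)but-3-en-1-yl, so it brought in the ring rather than changing one already present. Going by the values given here, no measured pair shows what swapping one substituted phenyl for another does, and compound 3 still carries a ring at this place. The expected change is therefore no larger than that modest step, and probably within the scatter, with no firm direction. The estimated move in this assay is a 1.0-fold higher number from compound 2 to compound 3 (0.01 log units; within the scatter) here. For compound 3 the estimate is 40000 nM, with an expected range from 15000 nM to 105000 nM.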

Compound 3, half-maximal inhibitory concentration: 25000 nM
Compound 3: the middle estimate sits 1.6-fold (0.20 log units) above what was measured, within the range that was stated.
By their numbers in this assay, from the lowest: compounds 3 and 2 (each within the scatter of the next); then compound 1.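

In this assay, putting 4-(methoxymethoxy)phenyl in place of 3-methoxyphenyl on a double-bonded chain carbon bound to a double-bonded chain carbon gives a 1.6-fold lower number from compound 2 to compound 3 (0.19 log units; within the scatter), so the two compounds cannot be told apart in this assay. Among the compounds shown here, the earlier step, a 3.5-fold lower number from compound 1 to compound 2 (0.54 log units; beyond the scatter), brought a ring into the molecule, whereas this pair is the first to keep a ring at this place and exchange one substituted phenyl for another; the entering group has 10 heavy atoms against 8 and 2 hydrogen-bond acceptors against 1, yet the number stays within the scatter. No measurement at hand gives a reason for this result.

This single pair changes both the substituent and its numbered place on the ring, so it cannot show whether either change alone would matter. It also leaves open what an amine or a carboxylic acid on this ring, or a longer chain leading to the ring, would do to the number in this assay.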